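Benzyl on the Oxime Oxygen: A Lipophilicity Estimate

The compounds below may be only part of what the source reports. "The series", "measured", "known", "first", "only" and "open" are said of these compounds alone.

Of the compounds shown here, three that share one core have been measured in a physicochemical assay for lipophilicity, using the shake flask method; on this read-out higher numbers stand for higher lipophilicity and lower numbers for lower lipophilicity. Compound 1 `N/N=C/c1c(N)ncnc1Oc1ccc(NC(=O)C2(C(=O)Nc3ccc(F)cc3)CC2)cc1F` gives 2.25. Compound 2 `Nc1ncnc(Oc2ccc(NC(=O)C3(C(=O)Nc4ccc(F)cc4)CC3)cc2F)c1/C=N/O` gives 2.62, and compound 3 `Nc1ncnc(Oc2ccc(NC(=O)C3(C(=O)Nc4ccc(F)cc4)CC3)cc2F)c1/C=N/OCCCO` gives 2.67. Compound 2 therefore stands second highest of the three: its nearest neighbour is compound 3, and the step of a number 0.05 log units higher from compound 2 to compound 3 (within the scatter) lies within the scatter, while the step of a number 0.37 log units higher from compound 1 to compound 2 (beyond the scatter) is beyond it, as is a number 0.42 log units higher from compound 1 to compound 3 (beyond the scatter).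

Compound 4 `Nc1ncnc(Oc2ccc(NC(=O)C3(C(=O)Nc4ccc(F)cc4)CC3)cc2F)c1/C=N/OCc1ccccc1` is not yet measured. It differs from compound 2 by benzyl in place of hydrogen on an oxygen. The measured step that bears most directly on this change is a number 0.05 log units higher from compound 2 to compound 3 (within the scatter), since there too a group replaced the hydrogen on the same oxygen. That group, 3-hydroxypropyl, carries a hydroxy group, whereas the entering benzyl counts no hydrogen-bond donors and no acceptors and brings a six-membered aromatic ring of carbon only. On that basis a rise beyond the scatter, larger than the step to compound 3, is expected for compound 4, amounting to a number 1.28 log units higher from compound 2 to compound 4 (beyond the scatter). Compound 4 is accordingly estimated at 3.9 in this assay, with a range from 3.2 to 4.6.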

Compound 4, partition coefficient: 4.45
Estimate against measurement, compound 4: 0.55 log units below; the measured number falls inside the stated range.
By their numbers in this assay, from the lowest: compound 1; then compounds 2 and 3 (each within the scatter of the next); then compound 4.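

Replacing the hydrogen on the oxygen is not a neutral change in this assay: benzyl gives a number 1.83 log units higher from compound 2 to compound 4 (beyond the scatter), a large step, whereas 3-hydroxypropyl gave only a number 0.05 log units higher from compound 2 to compound 3 (within the scatter). The identity of the entering group therefore matters, and not merely whether the hydrogen is replaced, as phenyl in place of 2-hydroxyethyl on the saturated chain carbon bound to that oxygen gives a number 1.78 log units higher from compound 3 to compound 4 (beyond the scatter). Set against amino on the double-bonded nitrogen, benzyloxy gives a number 2.20 log units higher from compound 1 to compound 4 (beyond the scatter), the widest step among these four compounds, and it shows that this site can move the read-out far more than the earlier steps suggested.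

The compounds shown leave open whether the rise follows the aromatic ring or simply the added carbon, which a plain propyl chain, a longer alkyl chain or a cyclohexylmethyl group on the same oxygen could separate, and whether an amine or a carboxylic acid on the benzyl ring would take back part of the step. No measurement offered here explains why benzyl has so much larger an effect than 3-hydroxypropyl.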